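Chloro step from compound 3 to compound 4

The source may hold more compounds than are shown below. What is called first, only, known or untested is meant among the compounds shown, and "the series" means these compounds.

Measured in a functional assay on Raji cells (Homo sapiens) for antiproliferative activity, read by MTT assay, with a stated time of 48 h; on this read-out lower numbers stand for stronger inhibition and higher numbers for weaker inhibition:
- compound 1 `CN1CCN(CCCn2c(N)c(-c3nc4ccccc4[nH]3)c3nc(C#N)c(C#N)nc32)CC1` gives 2620 nM
- compound 2 `N#Cc1nc2c(-c3nc4ccccc4[nH]3)c(N)n(CCCO)c2nc1C#N` gives > 50000 nM, which is a limit of the assay
- compound 3 `CCN(CC)CCCCn1c(N)c(-c2nc3ccccc3[nH]2)c2nc(C#N)c(C#N)nc21` gives 2640 nM

Compound 3 stands level with compound 1 (a 1.0-fold higher number from compound 1 to compound 3 (0.00 log units; within the scatter)) and well clear of the limit held by compound 2.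

Compound 4 `CCN(CC)CCCCn1c(N)c(-c2nc3cc(Cl)ccc3[nH]2)c2nc(C#N)c(C#N)nc21` carries chloro in place of hydrogen on an aromatic carbon and keeps the chain of compound 3. Among the measured compounds shown here, every measured step changes the chain end and none touches this ring, so the data hold no direct precedent. The large step (an at least 18-fold lower number from compound 2 to compound 3 (1.27 log units; beyond the scatter)) removes a hydroxy chain end, and compound 4 involves no such change. The step between the two amine chain ends stayed within the scatter (a 1.0-fold higher number from compound 1 to compound 3 (0.00 log units; within the scatter)). No step beyond the scatter is therefore expected in this assay, though the uncertainty is wide. The expected change is small (a 1.3-fold lower number from compound 3 to compound 4 (0.12 log units; within the scatter)). For compound 4 the estimate is 2000 nM, with an expected range from 650 nM to 6500 nM.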

Compound 4, half-maximal inhibitory concentration: 720 nM
Beside the measured number, compound 4's estimate is 2.8-fold (0.44 log units) above it; measured number inside the range.
By their numbers in this assay, from the lowest: compound 4; then compounds 1 and 3 (each within the scatter of the next). At a limit, above all of these: compound 2.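

In this assay the change from 1H-benzimidazol-2-yl to 5-chloro-1H-benzimidazol-2-yl gives a 3.7-fold lower number from compound 3 to compound 4 (0.56 log units; beyond the scatter) with the chain of compound 3 held fixed. This is the first step shown away from the chain end, and it shows that this aromatic carbon of the fused ring system can also move the number beyond the scatter. Nothing in the data shown accounts for the size of this step.

On these data alone, whether chloro gives a similar step on the 4-methylpiperazin-1-yl chain of compound 1 remains open. Also open, as far as these compounds go, is whether fluoro, bromo, methyl or methoxy on this carbon, or chloro on another carbon of the same ring, would match, exceed or lose the step seen with compound 4.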